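A few compounds are considered here, and "the series" means these few. Any claim that something is new, unique, unknown or untested is made for them only; others in the source may bear on it.

Measured compounds:
- compound 1 `CCn1nnc(-c2sc(-c3ccc(Cl)cc3)nc2O)n1`, in an assay on HEK293 cells for inhibition of transient receptor potential cation channel subfamily M member 8 (Homo sapiens), read by FLIPR, with stated times of 5 min and 3 min (on this read-out higher numbers stand for weaker inhibition and lower numbers for stronger inhibition), compound 1 gives 7550 nM
- compound 2 `CCOC(=O)Cc1sc(-c2ccccc2)nc1O`, in this assay compound 2 gives 950 nM

Compound 1 stands at the higher of the two numbers; compound 2 lies well below it, beyond the scatter. The next compound in the series is compound 3 `CCn1nnc(-c2sc(-c3ccc(F)cc3)nc2O)n1`, which differs from compound 1 by fluoro in place of chloro on an aromatic carbon. Among the compounds with values here, no measured pair shows what this exchange does, so the expectation rests on compound 1 alone. A small upward move in this assay is expected, possibly within the scatter: the step of a 1.6-fold higher number from compound 1 to compound 3 (0.20 log units; within the scatter) is the estimate. Compound 3 is expected to give 12000 nM, in the range 4000 nM to 35000 nM.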

Compound 3, half-maximal inhibitory concentration: 286 nM
Beside the measured number, compound 3's estimate is 42-fold (1.62 log units) above it; measured number outside the range, below it.
By their numbers in this assay, from the lowest: compound 3; then compound 2; then compound 1.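

In this assay, the aromatic carbon para to a large group proves highly sensitive to the identity of its halogen: fluoro in place of chloro gives a 26-fold lower number from compound 1 to compound 3 (1.42 log units; beyond the scatter). A change of a single heavy atom at this place is therefore enough to produce a large step in the series. No available evidence bears on the reason for this step.

The compounds shown leave open whether other groups at this place, such as hydrogen, methyl, methoxy or trifluoromethyl, would match fluoro or chloro.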